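Benzofuran in place of phenyl on a nucleoside series

The compounds below may be only part of what the source reports. "The series", "measured", "known", "first", "only" and "open" are said of these compounds alone.

Compound 3 `COc1ncnc2c1c(-c1ccccc1)cn2[C@@H]1O[C@H](CO)[C@@H](O)[C@H]1O` is the methoxy parent. In a functional assay on A549 cells (Homo sapiens), read by MTT assay, with a stated time of 72 h (on this read-out higher numbers stand for weaker inhibition and lower numbers for stronger inhibition), compound 3 gives only a limit, > 20000 nM. Compound 1 `COc1nc(N)nc2c1c(-c1ccccc1)cn2[C@@H]1O[C@H](CO)[C@@H](O)[C@H]1O` carries an amino group on the shared core; in this assay compound 1 also gives only a limit, > 20000 nM. The step that the two limits leave unreadable from compound 1 to compound 3 is thus unreadable, as the limit of > 20000 nM in this assay, at which 3 of the 3 values shown sit, records. Compound 2 `Cc1ncnc2c1c(-c1cc3ccccc3o1)cn2[C@@H]1O[C@H](CO)[C@@H](O)[C@H]1O`, a methyl analogue already bearing the benzofuran, in this assay gives only a limit, > 20000 nM. Compound 4 `COc1ncnc2c1c(-c1cc3ccccc3o1)cn2[C@@H]1O[C@H](CO)[C@@H](O)[C@H]1O` differs from compound 3 by 1-benzofuran-2-yl in place of phenyl on an aromatic carbon. For the measured compounds named here, no measured step reads this change; compound 2 shows the benzofuran at the limit. Compound 4 is therefore expected to stay at the limit, a step that the limit leaves unreadable from compound 3 to compound 4 of no readable size. The estimate for compound 4 is 40000 nM, ranging from 10000 nM to 150000 nM.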

Compound 4, half-maximal inhibitory concentration: 17700 nM
Beside the measured number, compound 4's estimate is 2.3-fold (0.35 log units) above it; low and high end bracket the measured number.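

Among the compounds shown, compound 4 alone gives a number rather than a limit in this assay. The change of phenyl to 1-benzofuran-2-yl gives an at least 1.1-fold lower number from compound 3 to compound 4 (0.05 log units; that floor lies within the scatter), and methoxy in place of methyl on an aromatic carbon gives an at least 1.1-fold lower number from compound 2 to compound 4 (0.05 log units; that floor lies within the scatter); these are floors, so neither change is shown to exceed the scatter. The other compounds give no readable step: the limit of > 20000 nM in this assay, at which 3 of the 4 values shown sit.

Open, on these data alone, is whether a longer alkoxy chain or an amine in place of methoxy moves the number of compound 4. Also open, as far as these compounds go, is what a carboxylic acid on the 1-benzofuran-2-yl would do.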